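Series notes: hydroxy for methoxy on the aryl ring

The source may hold more compounds than are shown below. What is called first, only, known or untested is meant among the compounds shown, and "the series" means these compounds.

Measured in a functional assay on EKVX cells (Homo sapiens) for cytotoxicity, read by sulforhodamine B assay, with a stated time of 48 h, tested at 1 uM; a higher number here means a weaker effect of the compound at the concentration tested, a lower number a stronger effect:
compound 1, `COc1cc(C)cc(-c2nn(CC#N)cc2-c2ccc(-c3cccc(C(C)=O)c3)nc2)c1`, gives 24%
compound 2, `Cc1cc(O)cc(-c2nn(CC#N)cc2-c2ccnc(-c3ccc(Oc4ccccc4)cc3)c2)c1`, gives -4%
compound 3, `COc1cc(C)cc(-c2nn(CC#N)cc2-c2ccnc(-c3ccc(N(C)C)cc3)c2)c1`, gives 28%

Compound 3 stands at the highest of the three numbers, but its nearest neighbour, compound 1, lies within the scatter of it, so no order between the two can be read. Compound 2 lies well beyond the scatter below compound 3, the only clear separation in the set.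

The next compound, compound 4, `Cc1cc(O)cc(-c2nn(CC#N)cc2-c2ccnc(-c3ccc(N(C)C)cc3)c2)c1`, has not been measured in this assay. It differs from compound 3 in one place: hydrogen in place of methyl on an oxygen on an aromatic ring. Read one bond further out, this is methoxy to hydroxy, so the 3-methoxy-5-methylphenyl of compound 3 becomes 3-hydroxy-5-methylphenyl.

Among the compounds with values here, no measured pair in the set isolates this change. Within the data shown here, compound 2, the only other compound carrying the hydroxy, gives -4%, but it differs from compound 4 in more than one place, so it guides the estimate only loosely. The step of a number 13 percentage points lower from compound 3 to compound 4 (beyond the scatter) is expected to run downward, of a size at the edge of the scatter. Compound 4 is therefore estimated at 15%, within a range from -8% to 38%.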

Compound 4, a percentage reported as activity, at one concentration (the size of the read-out at that concentration, not a potency): 29%
For compound 4 the middle estimate is 14 percentage points below the measured one; low and high end bracket the measured number.
By their numbers in this assay, from the lowest: compound 2; then compounds 1, 3 and 4 (each within the scatter of the next).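

In this assay, within the data shown here, the first pair to isolate methoxy to hydroxy on the aryl ring gives a number 1 percentage points higher from compound 3 to compound 4 (within the scatter), so with dimethylamino in place, this position shows no readable response to the loss of the methyl on the oxygen. The low number of compound 2 therefore cannot be read as a general mark of the hydroxy: with the 3-hydroxy-5-methylphenyl held constant, dimethylamino in place of phenoxy on an aromatic carbon gives a number 33 percentage points higher from compound 2 to compound 4 (beyond the scatter), a large step that places the clear separation in this set at that other site. No supporting measurement bears on why the first step stays so small or the second runs so large.

The compounds shown leave open whether methoxy to hydroxy would read the same with phenoxy at that other site, so any dependence of this change on its partner group remains untested here. Also open, as far as these compounds go, is how this position responds to an amine in place of the hydroxy, or to a longer chain such as ethyl on the oxygen.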